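Swapping the Amine on the Thiocarbonyl Carbon

The source may hold more compounds than are shown below. What is called first, only, known or untested is meant among the compounds shown, and "the series" means these compounds.

Three compounds share a core in which a thiocarbonyl carbon carries both a sulfur and a ring amine, and they were compared in a functional assay on HeLa cells (Homo sapiens) for antiproliferative activity, read by CCK-8 assay, with a stated time of 72 h, tested at 8 uM; a higher number here means a stronger effect of the compound at the concentration tested, a lower number a weaker effect. Compound 1 `CC1CCCCN1C(=S)SCc1ccc(C(=O)Nc2ccccc2N)cc1` gives 76.3% and stands highest of the three measured values. Among the compounds with values here, compound 2 `COc1ccc(N2CCN(C(=S)SCc3ccc(C(=O)Nc4ccccc4N)cc3)CC2)cc1` gives 52.3%, and compound 3 `Nc1ccccc1NC(=O)c1ccc(CSC(=S)N2CCN(Cc3ccccc3)CC2)cc1` gives 31.3%; the one measured step between neighbours shows a number 21 percentage points lower from compound 2 to compound 3 (beyond the scatter). Compound 1 thus lies well clear of both, with compound 2 nearest and compound 3 furthest.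

Compound 4 `Nc1ccccc1NC(=O)c1ccc(CSC(=S)N2CCc3cc(Cl)ccc32)cc1` has not yet been measured in this assay. It differs from compound 1 in one place: 5-chloro-2,3-dihydro-1H-indol-1-yl in place of 2-methylpiperidin-1-yl on a thiocarbonyl carbon.

Within the data shown here, no measured pair repeats exactly this exchange. The step from compound 2 to compound 3 changes the amine part at a more distant point, yet it still moved the read-out by a modest amount, and both compound 2 and compound 3 sit far under compound 1. Every measured departure from the 2-methylpiperidin-1-yl group of compound 1 has therefore come with a lower number, which suggests a drop beyond the scatter here as well, though its size is uncertain. Compound 4 is expected to give about 55%, within a range from 35% to 75%, which would mean an expected step of a number 21.3 percentage points lower from compound 1 to compound 4 (beyond the scatter).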

Compound 4, a percentage reported as inhibition, at one concentration (the size of the read-out at that concentration, not a potency): 65.1%
Beside the measured number, compound 4's estimate is 10.1 percentage points below it; low and high end bracket the measured number.
By their numbers in this assay, from the lowest: compound 3; then compound 2; then compound 4; then compound 1.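

In this assay the exchange gives a number 11.2 percentage points lower from compound 1 to compound 4 (beyond the scatter) and so leaves the 2-methylpiperidin-1-yl group ahead, but the loss is modest and much of the read-out remains. This position on the thiocarbonyl carbon therefore accepts a larger group, one that brings a chlorine and a six-membered aromatic ring of carbon only, while compound 4 still gives 65.1% in this assay. Nothing measured here bears on why the number falls.

The compounds shown do not separate the chlorine from the rest of the 5-chloro-2,3-dihydro-1H-indol-1-yl group, so the same group carrying a hydrogen, a fluorine or a methoxy group in place of that chlorine would be the telling comparison. They also leave open what the methyl of the 2-methylpiperidin-1-yl group contributes, which a plain piperidin-1-yl group would test, and how an open-chain amine such as diethylamino would fare on the thiocarbonyl carbon.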